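The source may report more compounds than this note shows. Statements on the series, on what has been measured and on what is new or still open speak of the compounds shown alone.

Measured compounds:
- compound 1 `CO[C@H]1O[C@H](COc2ccc(C3CCCCC3)cc2)[C@@H](O)[C@H](O)[C@H]1Oc1cccc2c1CCCC2`: 28000 nM
- compound 2 `CO[C@@H]1O[C@H](COc2ccc(-c3ccccc3)cc2)[C@@H](O)[C@H](O)[C@H]1Oc1ccccc1`: "not determined" (no result reported)

Within the data shown here, compound 1 is the only compound with a number in a functional assay on A549 cells (Homo sapiens) for cytotoxicity, read by MTT assay, with a stated time of 48 h; on this read-out higher numbers stand for an effect only at larger amounts of compound and lower numbers for an effect already at smaller amounts; compound 1 gives 28000 nM there. Compound 2 was entered in this assay but no result was reported, so nothing can be said of where it stands.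

Compound 3 `CO[C@H]1O[C@H](COc2ccc(C3CCCCC3)cc2)[C@@H](O)[C@H](O)[C@H]1Oc1ccc2c(c1)CCCC2` has the same atoms as compound 1, joined differently: 1,2,3,4-tetrahydronaphthalen-6-yl in place of 1,2,3,4-tetrahydronaphthalen-5-yl on an oxygen on a saturated carbon. The change keeps the two rings of the group and moves only the point at which the group is attached to the oxygen.

Among the measured compounds shown here, no step between measured compounds is available to set the size of such a change. With a shift of attachment on an otherwise unchanged group, the expectation is a step from compound 1 to compound 3 of no change at the digits printed from compound 1 to compound 3 (within the scatter), that is, none beyond the scatter in either direction. Compound 3 is therefore estimated to give 28000 nM in this assay, with a range from 12000 nM to 65000 nM.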

Compound 3, half-maximal effective concentration: 17000 nM
The estimate for compound 3 lay 1.6-fold (0.22 log units) above the measured number; the measured number falls inside the stated range.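

In this assay the swap of 1,2,3,4-tetrahydronaphthalen-5-yl for 1,2,3,4-tetrahydronaphthalen-6-yl on this oxygen gives a 1.6-fold lower number from compound 1 to compound 3 (0.22 log units; within the scatter) and so does not separate the two compounds on this read-out. Among these compounds, this pair offers the first comparison at this position, and it shows that, with the rest of the molecule unchanged, either point of attachment of this group gives a similar result. Nothing available explains this similarity.

The compounds shown cover only these two attachments of a single group, so they cannot tell whether this position responds to a different kind of group. A group carrying an amine or a carboxylic acid on this oxygen, for example, could give a quite different number, and the two values here do not predict it.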